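A few compounds are considered here, and "the series" means these few. Any claim that something is new, unique, unknown or untested is made for them only; others in the source may bear on it.

Series notes. Compound 1 `O=c1cc(CN(c2cccc(Cl)c2)c2ccccn2)c2ccc(F)c(F)c2[nH]1` is the reference point: in an assay on HEK293 cells for inhibition of Nitric oxide synthase, inducible (Homo sapiens), read by fluorescence (on this read-out higher numbers stand for weaker inhibition and lower numbers for stronger inhibition), compound 1 gives 31 nM. Compound 2 `Cc1cccnc1N(Cc1cc(=O)[nH]c2c(F)c(F)ccc12)c1cccc(Cl)c1` carries a methyl in place of hydrogen on an aromatic carbon; the step is an 11-fold higher number from compound 1 to compound 2 (1.05 log units; beyond the scatter). For the measured compounds named here, on the two numbers so far, compound 2 stands highest, with 350 nM, weaker than compound 1 by a margin beyond the scatter.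

Compound 3 `CN(C)c1nccc(N(Cc2cc(=O)[nH]c3c(F)c(F)ccc23)c2cccc(Cl)c2)n1` is not yet measured. Its change from compound 2 is 2-(dimethylamino)pyrimidin-4-yl in place of 3-methylpyridin-2-yl on a nitrogen on an aromatic ring. Going by the values given here, the one measured step, the methyl addition from compound 1 to compound 2, does not touch this kind of exchange, so no measured step bears on it directly, and the direction of the step is open. The estimate for compound 3 therefore rests on compound 2 with a wide range, and the expected step is a 1.2-fold lower number from compound 2 to compound 3 (0.07 log units; within the scatter). Compound 3 is expected to give 300 nM, within 60 nM to 1500 nM.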

Compound 3, half-maximal inhibitory concentration: 1300 nM
The estimate for compound 3 lay 4.3-fold (0.64 log units) below the measured number; the range from low to high includes it.
By their numbers in this assay, from the lowest: compound 1; then compound 2; then compound 3.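

In this assay, the position on the nitrogen tolerates more than the methyl change alone would indicate, and not in compound 3's favour: 2-(dimethylamino)pyrimidin-4-yl in place of 3-methylpyridin-2-yl gives a 3.7-fold higher number from compound 2 to compound 3 (0.57 log units; beyond the scatter). Measured against the plain pyridin-2-yl, the same exchange gives a 42-fold higher number from compound 1 to compound 3 (1.62 log units; beyond the scatter), so both substituted rings at this place stand weaker than pyridin-2-yl, and compound 3 is the weakest of the three. No measurement at hand accounts for either step.

Compound 3 alters the ring's hetero atoms and adds a dimethylamino group in one exchange, so the share of each in the step stays unresolved. As far as these compounds go, whether a bare pyrimidin-4-yl, or a pyridin-2-yl carrying a methoxy group or a primary amine, would stay near compound 1 remains open.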